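The compounds below may be only part of what the source reports. "The series", "measured", "known", "first", "only" and "open" are said of these compounds alone.

In an ADME assay on HepG2 cells (Homo sapiens) for cytotoxicity (a higher number here means that more compound is needed for the effect, a lower number that less compound is needed), compound 1 (`COc1cccc(C(=O)NCCNC(=O)[C@H](CC(=O)NC(C)(C)C)NS(=O)(=O)c2ccc(C)cc2)c1`) gives > 11000 nM as a limit of the assay, not a number. Compound 2 (`Cc1ccc(S(=O)(=O)N[C@@H](CC(=O)NC(C)(C)C)C(=O)NCCNC(=O)c2ccc(F)c(F)c2)cc1`) gives > 11000 nM and this too is only a limit. Compound 2 therefore has no readable position of its own, since both values shown sit at the same limit (the limit of > 11000 nM in this assay, at which 2 of the 2 values shown sit). Compound 3 (`Cc1ccc(S(=O)(=O)N[C@@H](CC(=O)NC(C)(C)C)C(=O)NCCNC(=O)c2cccc(C(F)(F)F)c2)cc1`) differs from compound 2 by carrying 3-(trifluoromethyl)phenyl in place of 3,4-difluorophenyl on a carbonyl carbon. Within the data shown here, one measured step bears on this place (a step that the two limits leave unreadable from compound 1 to compound 2) and its size cannot be read. No shift beyond the scatter is therefore expected in this assay and no direction can be assigned. The expected change is a step that the limit leaves unreadable from compound 2 to compound 3 as estimated here. Compound 3 is expected at about 15000 nM within an estimated range from 8000 nM to 30000 nM and may again come out only as a limit.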

Compound 3, half-maximal effective concentration: > 11000 nM
Compound 3 ended at the assay's limit (the forecaster's own chance of this, stated with the estimate: 85%); the middle value does not contradict the limit.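

No step among compound 1, compound 2 and compound 3 can be read, and compound 3 adds only another limit of the assay, not a number: the limit of > 11000 nM in this assay, at which 3 of the 3 values shown sit.

The compounds shown leave open whether any change at this place on the carbonyl carbon shifts the result in this assay at all.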